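The source may hold more compounds than are shown below. What is called first, only, known or untested is meant among the compounds shown, and "the series" means these compounds.

Measured so far: compound 1, `C[S+]([O-])c1c(F)c(N)c2c(=O)cc(-c3ccc(N)c(F)c3)oc2c1F`; compound 2, `CCOC(=O)c1c(F)c(N)c2c(=O)cc(-c3ccc(N)c(F)c3)oc2c1F`.

In a functional assay on HeLa cells (Homo sapiens) for cytotoxicity, read by neutral red uptake, with a stated time of 3 days (on this read-out lower numbers stand for stronger inhibition and higher numbers for weaker inhibition), compound 1 gives > 100000 nM, which is a limit of the assay and not a number. In this assay compound 2 gives > 100000 nM, which is likewise a limit of the assay. Compound 2 therefore stands where every value shown stands: the limit of > 100000 nM in this assay, at which 2 of the 2 values shown sit. Within the data shown here, the only measured step, a step that the two limits leave unreadable from compound 1 to compound 2, cannot be read, since both of its ends are limits.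

Compound 3, `CCC(=O)OCc1c(F)c(N)c2c(=O)cc(-c3ccc(N)c(F)c3)oc2c1F`, differs from compound 2 in one place: (propanoyloxy)methyl in place of ethoxycarbonyl on an aromatic carbon. No measured step bears directly on this change, and the single step shown gives no readable size. With both measured compounds sitting at the limit, compound 3 is expected to stay there as well, so the expected step of a number no higher from compound 2 to compound 3 (the limit leaves the size open) is none beyond the scatter. The estimate for compound 3 is 100000 nM, with a range from 30000 nM to 300000 nM.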

Compound 3, half-maximal inhibitory concentration: 69000 nM
Compound 3: the middle estimate sits 1.4-fold (0.16 log units) above what was measured; the measured number falls inside the stated range.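

In this assay, among these compounds, compound 3 gives 69000 nM, the first value at this position, on an aromatic carbon ortho to two fluoro groups, that is a number and not a limit. Putting (propanoyloxy)methyl in place of ethoxycarbonyl gives an at least 1.4-fold lower number from compound 2 to compound 3 (0.16 log units; that floor lies within the scatter), and putting the same group in place of the sulfur-containing group gives an at least 1.4-fold lower number from compound 1 to compound 3 (0.16 log units; that floor lies within the scatter), so neither change can yet be told apart from ordinary assay variation, although the true size of each step may be larger. The step between the two limits cannot be read, and most of the series still gives no number: the limit of > 100000 nM in this assay, at which 2 of the 3 values shown sit.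

The compounds shown leave open how an amine, a carboxylic acid or a longer ester chain at this position would read. They also leave open whether any group here can bring the number down by more than the scatter.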